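Urea substituent variation on the shared core: compound 4

A few compounds are considered here, and "the series" means these few. Any claim that something is new, unique, unknown or untested is made for them only; others in the source may bear on it.

Measured so far:
- compound 1, `COc1ccccc1NC(=O)N1CCC(c2nc(-c3ccc4ccccc4n3)no2)CC1`: 410 nM
- compound 2, `O=C(NC1CC[S+]([O-])CC1)N1CCC(c2nc(-c3ccc4ccccc4n3)no2)CC1`: 850 nM
- compound 3, `O=C(Nc1cccnc1Cl)N1CCC(c2nc(-c3ccc4ccccc4n3)no2)CC1`: 1600 nM

Compound 1 gives the lowest number of the three in a functional assay on Shh Light II cells (Mus musculus) for inhibition, read by a luciferase reporter; on this read-out lower numbers stand for stronger inhibition and higher numbers for weaker inhibition. The nearest is compound 2, reached by a 2.1-fold higher number from compound 1 to compound 2 (0.32 log units; beyond the scatter); the furthest is compound 3, reached by a 3.9-fold higher number from compound 1 to compound 3 (0.59 log units; beyond the scatter). Between compound 2 and compound 3 the step is a 1.9-fold higher number from compound 2 to compound 3 (0.27 log units; within the scatter), so these two cannot be ordered against each other. Every measured change so far has replaced the 2-methoxyphenyl on the amide-type nitrogen and every such replacement has raised the number.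

Compound 4, `O=C(N1CCC(c2nc(-c3ccc4ccccc4n3)no2)CC1)N1CCCc2ccccc21`, is the next member. It differs from compound 1 as follows: 1,2,3,4-tetrahydroquinolin-1-yl in place of (2-methoxyphenyl)amino on a carbonyl carbon. Here the whole (2-methoxyphenyl)amino group leaves the carbonyl carbon and the nitrogen becomes part of a ring, so the change is larger than those measured. Both steps from compound 1, to compound 2 and to compound 3, bear on it only loosely, as each swapped the group on this nitrogen and each weakened inhibition. A modest upward step in this assay is therefore expected for compound 4, of about a 2.4-fold higher number from compound 1 to compound 4 (0.39 log units; beyond the scatter). The expected value for compound 4 is 1000 nM, with a range from 300 nM to 3500 nM.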

Compound 4, half-maximal inhibitory concentration: 2300 nM
The estimate for compound 4 lay 2.3-fold (0.36 log units) below the measured number; the range from low to high includes it.
By their numbers in this assay, from the lowest: compound 1; then compounds 2, 3 and 4 (each within the scatter of the next, the first and the last beyond it).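

With compound 4 the carbonyl carbon carries a second ring nitrogen and no amide hydrogen on that side, and in this assay this is the first change on this carbonyl to move the number this far (a 5.6-fold higher number from compound 1 to compound 4 (0.75 log units; beyond the scatter)), which leaves compound 1 the strongest of the four, with no listed replacement of its (2-methoxyphenyl)amino group going against that. The other two steps do not isolate the amide hydrogen: compound 3 keeps that hydrogen, yet it cannot be ordered against compound 4 (a 1.4-fold higher number from compound 3 to compound 4 (0.16 log units; within the scatter)), whereas compound 2, which also keeps it, does separate from compound 4 (a 2.7-fold higher number from compound 2 to compound 4 (0.43 log units; beyond the scatter)). No measurement at hand accounts for these differences.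

The compounds shown leave open whether the rise from compound 1 to compound 4 goes with the loss of the amide hydrogen or with the closing of the ring, and an open-chain N-methyl-N-(2-methoxyphenyl)amino group on the same carbonyl would separate the two. Also open, on these data alone, is whether a ring nitrogen without a fused benzene ring, such as piperidin-1-yl or morpholin-4-yl, behaves like 1,2,3,4-tetrahydroquinolin-1-yl at this place.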